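The source may report more compounds than this note shows. Statements on the series, on what has been measured and on what is new or still open speak of the compounds shown alone.

Measured so far:
compound 1, `NC[C@@H]1CCCc2cc(S(=O)(=O)c3cccc(F)c3)ccc21`: 0.0794 nM
compound 2, `NC[C@@H]1CCCc2cc(S(=O)(=O)Cc3ccccc3)ccc21`: 158 nM
compound 3, `NC[C@@H]1CCCc2cc(S(=O)(=O)c3cc[nH]c3)ccc21`: 0.316 nM

All three share one core and differ only in the group carried on the sulfonyl sulfur. In an assay on isolated protein for displacement of a labelled ligand from 5-hydroxytryptamine receptor 6 (Homo sapiens) (on this read-out lower numbers stand for stronger inhibition and higher numbers for weaker inhibition), compound 3 gives 0.316 nM, the second highest of the three numbers. Against the fluorophenyl compound the step was modest: a 4.0-fold higher number from compound 1 to compound 3 (0.60 log units; beyond the scatter). Against the benzyl compound it was large: a 500-fold lower number from compound 2 to compound 3 (2.70 log units; beyond the scatter).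

Compound 4, `Cn1ccc(S(=O)(=O)c2ccc3c(c2)CCC[C@H]3CN)c1`, has not been measured yet. It differs from compound 3 in one place: methyl in place of hydrogen on an aromatic nitrogen. Neither measured step tests this kind of change directly, since both of them exchange the whole group on the sulfonyl sulfur, whereas here the five-membered ring is kept and only the hydrogen on its aromatic nitrogen gives way to methyl. What the data do show is that exchanging one aromatic ring for another moved the number modestly, while moving to benzyl moved it greatly. For so small an alteration the expected step is a 1.3-fold higher number from compound 3 to compound 4 (0.10 log units; within the scatter), that is, nothing clearly beyond the scatter. Compound 4 is therefore estimated at 0.4 nM, with a range from 0.1 nM to 1.6 nM.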

Compound 4, inhibition constant: 7.94 nM
For compound 4 the middle estimate is 20-fold (1.30 log units) below the measured one; the measured number lies above the stated range.
By their numbers in this assay, from the lowest: compound 1; then compound 3; then compound 4; then compound 2.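

In this assay, the nitrogen of the five-membered ring proves sensitive to a very small edit: putting methyl in place of its hydrogen gives a 25-fold higher number from compound 3 to compound 4 (1.40 log units; beyond the scatter), a larger step than a 4.0-fold higher number from compound 1 to compound 3 (0.60 log units; beyond the scatter) seen on exchanging one whole aromatic ring for another. The methylated ring still leaves compound 4 on the favourable side of the benzyl compound, with a 20-fold lower number from compound 2 to compound 4 (1.30 log units; beyond the scatter), but well short of the fluorophenyl compound, with a 100-fold higher number from compound 1 to compound 4 (2.00 log units; beyond the scatter). Within the data shown here, nothing available explains why this single methyl moves the number so far.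

The compounds shown cannot separate the loss of the hydrogen from the arrival of the carbon. They also leave open whether ethyl or a longer chain on that nitrogen would raise the number further.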